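The compounds below may be only part of what the source reports. "The series", "measured", "known", "first", "only" and "open" are said of these compounds alone.

In an ADME assay on microsomes from liver (Rattus norvegicus) for metabolic stability, read by HPLC, using NADPH, tested at 1 mM (on this read-out lower numbers stand for slow clearance and higher numbers for fast clearance), three compounds have been measured:

compound 1, `COc1cc(NC(C)CCCNC(=O)C2CCC3(CC2)OOC2(OO3)C3CC4CC(C3)CC2C4)c2ncccc2c1-c1ccc(F)cc1`, gives 34.6 uL/min;
compound 2, `COc1cc(NC(C)CCCNC(=O)C2CCC3(CC2)OOC2(OO3)C3CC4CC(C3)CC2C4)c2ncccc2c1-c1ccc(Cl)cc1`, gives 10.7 uL/min;
compound 3, `COc1cc(NC(=O)C2CCC3(CC2)OOC2(OO3)C3CC4CC(C3)CC2C4)c2ncccc2c1-c1ccc(F)cc1`, gives 23.1 uL/min.

One single change links compound 1 to compound 2: chloro in place of fluoro on an aromatic carbon. In this assay this produced a 3.2-fold lower number from compound 1 to compound 2 (0.51 log units; beyond the scatter), a step beyond the usual scatter of the measurement. Compound 3 is built on a different core, and the difference between the two cores is not broken down here. Its value in this assay lies within the scatter of that of compound 1, so nothing can be said about their order, while it sits beyond the scatter from that of compound 2.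

Compound 4, `COc1cc(NC(=O)C2CCC3(CC2)OOC2(OO3)C3CC4CC(C3)CC2C4)c2ncccc2c1-c1ccc(Cl)cc1`, has not yet been measured. It differs from compound 3 by chloro in place of fluoro on an aromatic carbon, at a place described in the same words as the change from compound 1 to compound 2, so it is the same change made on the other core. Among the measured compounds shown here, the expectation for compound 4 in this assay is a step of about a 2.4-fold lower number from compound 3 to compound 4 (0.39 log units; beyond the scatter), somewhat smaller than the one seen on the first core because a 3.2-fold lower number from compound 1 to compound 2 (0.51 log units; beyond the scatter) is the only example available and a single step may not carry over in full. Compound 4 is therefore estimated at 9.5 uL/min, with a likely range from 4.5 uL/min to 20 uL/min.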

Compound 4, intrinsic clearance in a liver preparation (reported as CLH), per the amount of preparation that the assay uses: 11.1 uL/min
For compound 4 the middle estimate is 1.2-fold (0.07 log units) below the measured one; the measured number falls inside the stated range.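

In this assay, putting 4-chlorophenyl in place of 4-fluorophenyl on the core of compound 3 gives a 2.1-fold lower number from compound 3 to compound 4 (0.32 log units; beyond the scatter) and so points the same way as the change did on the core of compound 1. Read side by side, the two steps agree in direction and cannot be told apart in size: the same change on two cores in this assay, a 3.2-fold lower number (0.51 log units; beyond the scatter) from compound 1 to compound 2 and a 2.1-fold lower number (0.32 log units; beyond the scatter) from compound 3 to compound 4, 1.6-fold (0.19 log units) apart, within the scatter of two such steps. This shows that, on these two cores, the swap from fluoro to chloro carried over from one core to the other in this read-out, but two pairs are a small sample: they do not show that it would hold on a third core, and they do not explain why the number falls.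

From the compounds shown here alone, whether bromo, methyl or trifluoromethyl at the same place on the phenyl ring would lower the number further, or raise it, remains open. Also open, going by these compounds, is how the step would behave on a core with a longer chain or a different amine in the linking part.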